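The source may hold more compounds than are shown below. What is called first, only, known or untested is meant among the compounds shown, and "the series" means these compounds.

Measured compounds:
- compound 1, `COc1ccc(/C=C\c2cc(OC)c(OC)c(OC)c2)cc1OCc1ccc(C=O)cc1`: 900 nM
- compound 2, `COc1ccc(/C=C\c2cc(OC)c(OC)c(OC)c2)cc1OCc1ccc(CNCCO)cc1`: 1200 nM

In a functional assay on MC-38 cells (Mus musculus) for antiproliferative activity, read by CCK-8 assay, with a stated time of 48 h (on this read-out higher numbers stand for weaker inhibition and lower numbers for stronger inhibition), compound 1 gives 900 nM, the lowest of the two numbers shown, and compound 2 gives 1200 nM. Among the compounds with values here, the only measured step, a 1.3-fold higher number from compound 1 to compound 2 (0.12 log units; within the scatter), exchanges the formyl group on an aromatic carbon for a ((2-hydroxyethyl)amino)methyl group and lies within the scatter, so the two values cannot be told apart.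

Compound 3, `COc1ccc(/C=C\c2cc(OC)c(OC)c(OC)c2)cc1OCc1ccc(CNCCN(C)C)cc1`, has not yet been measured in this assay. Compared with compound 1 it differs as follows: ((2-(dimethylamino)ethyl)amino)methyl in place of formyl on an aromatic carbon. Within the data shown here, the single measured step bears directly on this change, since it too replaces the formyl group with an amine-bearing chain, and it was a 1.3-fold higher number from compound 1 to compound 2 (0.12 log units; within the scatter). On that basis the step is expected to be a 1.2-fold higher number from compound 1 to compound 3 (0.09 log units; within the scatter), that is, no change beyond the scatter. Compound 3 is therefore estimated at 1100 nM, with a range from 500 nM to 2500 nM.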

Compound 3, half-maximal inhibitory concentration: 1400 nM
Compound 3: middle estimate off by 1.3-fold (0.10 log units), on the low side; the range from low to high includes it.
By their numbers in this assay, from the lowest: compounds 1, 2 and 3 (each within the scatter of the next).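

In this assay, the step of a 1.6-fold higher number from compound 1 to compound 3 (0.19 log units; within the scatter) shows that a second amine-bearing chain, ((2-(dimethylamino)ethyl)amino)methyl, can also stand in place of formyl on this aromatic carbon, para to a large group, with no difference that can be told from the scatter. The new comparison at the chain end, with dimethylamino in place of hydroxy, gives a 1.2-fold higher number from compound 2 to compound 3 (0.07 log units; within the scatter), so these two end groups cannot be told apart in this read-out either. No measurement at hand explains these numbers.

On these data alone, with all three compounds lying within the scatter of one another, it remains open whether this position would respond to a different kind of group, such as a carboxylic acid or a morpholine ring. As far as these compounds go, it also remains open whether a longer chain between the two nitrogens would move the number beyond the scatter.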